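Amide variations on a shared core: cyclopropyl replaces chloropyridinyl

The source may hold more compounds than are shown below. What is called first, only, known or untested is meant among the compounds shown, and "the series" means these compounds.

Measured compounds:
Compound 1 `COc1cc2nccc(Oc3ccc4c(NC(=O)Nc5ccc(C(F)(F)F)cc5Cl)nn(C)c4c3)c2cc1OC`; in a functional assay on HUVEC cells (Homo sapiens) for inhibition, with stated times of 2 h and 72 h (on this read-out lower numbers stand for stronger inhibition and higher numbers for weaker inhibition), compound 1 gives > 1000 nM, which is a limit of the assay and not a number.
Compound 2 `COc1cc2nccc(Oc3ccc4c(NCc5ccccc5)nn(C)c4c3)c2cc1OC`; in this assay compound 2 gives > 1000 nM, again a limit.
Compound 3 `COc1cc2nccc(Oc3ccc4c(NC(=O)c5cc(Cl)ccn5)nn(C)c4c3)c2cc1OC`; in this assay compound 3 gives > 1000 nM, also a limit.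

Compound 3 therefore stands nowhere in particular on the numbers shown: all three values sit at the same limit, (the limit of > 1000 nM in this assay, at which 3 of the 3 values shown sit), so no order among compound 1, compound 2 and compound 3 can be read.

The next step leads to compound 4 `COc1cc2nccc(Oc3ccc4c(NC(=O)C5CC5)nn(C)c4c3)c2cc1OC`. The change is cyclopropyl in place of 4-chloropyridin-2-yl on a carbonyl carbon.

Two measured steps end at compound 3 and thus bear on it: a step that the two limits leave unreadable from compound 1 to compound 3 and a step that the two limits leave unreadable from compound 2 to compound 3. Both are unreadable in size, since each joins two limits. They give no direction for the change at the carbonyl carbon, and nothing in the series shows a number at all.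

On this basis the expectation for compound 4 in this assay is a step that the limit leaves unreadable from compound 3 to compound 4, that is no readable movement, with the result most likely again reported as a limit. The estimated value for compound 4 is 2000 nM, within a range from 500 nM to 8000 nM.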

Compound 4, half-maximal inhibitory concentration: > 1000 nM
Compound 4 ended at the assay's limit (the forecaster's own chance of this, stated with the estimate: 70%); the middle value does not contradict the limit.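

In this assay compound 4 gives > 1000 nM as a limit of the assay and not a number. Going by these compounds alone, no step joining compound 4 to compound 1, compound 2 or compound 3 can be read, since all four compounds share one limit: the limit of > 1000 nM in this assay, at which 4 of the 4 values shown sit. The compounds shown leave open whether any change on the shared core gives a measurable inhibition value.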